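Nitro for Methylsulfonyl Across Two Cores at the Receptor

The compounds below may be only part of what the source reports. "The series", "measured", "known", "first", "only" and "open" are said of these compounds alone.

Of the compounds shown here, three have been measured in an assay on THP-1 cells for antagonist activity at P2X purinoceptor 7 (Homo sapiens), read by ELISA, with a stated time of 30 min; a lower number here means a stronger inhibitor, a higher number a weaker inhibitor. Compound 1 `CS(=O)(=O)c1ccc(C(=O)N2CCN(c3cc(=O)[nH]c(=O)n3Cc3ccc(OS(=O)(=O)c4cccc5cnccc45)cc3)CC2)cc1` gives 50 nM. Compound 2 `O=C(c1ccc([N+](=O)[O-])cc1)N1CCN(c2cc(=O)[nH]c(=O)n2Cc2ccc(OS(=O)(=O)c3cccc4cnccc34)cc2)CC1` differs from compound 1 by one change, (nitro in place of methylsulfonyl on an aromatic carbon), and compound 2 gives 32 nM; the change is recorded as a 1.6-fold lower number from compound 1 to compound 2 (0.19 log units; within the scatter). Compound 3 `CS(=O)(=O)c1ccc(C(=O)N2CCC(c3nc4cc(OS(=O)(=O)c5cccc6cnccc56)ccc4[nH]3)CC2)cc1` is built on a different core; how its core differs from that of compound 1 is not broken down here. In this assay compound 3 gives 43 nM, a number that sits among the other two within the scatter, so no order among compounds 1, 2 and 3 can be read from these values.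

Compound 4 `O=C(c1ccc([N+](=O)[O-])cc1)N1CCC(c2nc3cc(OS(=O)(=O)c4cccc5cnccc45)ccc3[nH]2)CC1` has not yet been measured. It stands to compound 3 as compound 2 stands to compound 1: the change is nitro in place of methylsulfonyl on an aromatic carbon, and the description of the place is the same word for word in both cases, so the two changes are the same change made on two cores. Among the compounds shown this change occurs twice in all.

The expectation for compound 4 rests on a single precedent. Because the earlier step of a 1.6-fold lower number from compound 1 to compound 2 (0.19 log units; within the scatter) lay within the scatter, the step for compound 4 is estimated to be about as small: a 1.6-fold lower number from compound 3 to compound 4 (0.20 log units; within the scatter). Compound 4 is therefore estimated to give 27 nM in this assay, with a plausible range from 12 nM to 60 nM.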

Compound 4, half-maximal inhibitory concentration: 17 nM
Compound 4: the middle estimate sits 1.6-fold (0.20 log units) above what was measured; the range from low to high includes it.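

In this assay, putting nitro in place of methylsulfonyl, which turns the 4-(methylsulfonyl)phenyl group into 4-nitrophenyl, gives a 2.5-fold lower number from compound 3 to compound 4 (0.40 log units; beyond the scatter), a modest step that lies beyond the scatter. The size of this step cannot be told apart from that of the same change on the core of compound 1: the same change on two cores in this assay, a 1.6-fold lower number (0.19 log units; within the scatter) from compound 1 to compound 2 and a 2.5-fold lower number (0.40 log units; beyond the scatter) from compound 3 to compound 4, 1.6-fold (0.21 log units) apart, within the scatter of two such steps. The two pairs therefore show that the change can be carried from one core to the other without any measurable dependence on the core, but they do not show that the step is truly larger on the core of compound 3, and the step on the core of compound 1 does not by itself establish a real gain, as it stays within the scatter; two pairs in a single assay also say nothing about any further core or about why the numbers fall as they do.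

Still open, on these data alone, is how an amine, a carboxylic acid or a nitrile would compare with nitro at the same place, on an aromatic carbon para to a large group, on either core. As far as these compounds go, it is also open whether the pairing of these two groups would hold on a third core.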